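The source may report more compounds than this note shows. Statements on the series, on what has been measured and on what is new or still open speak of the compounds shown alone.

Among the measured compounds shown here, compound 1 `Fc1ccc(/C=N/NC(=S)Nc2cccc3ccccc23)cc1Cl` holds the only actual number in an ADME assay on NIH3T3 cells (Mus musculus) for cytotoxicity, read by XTT assay, with a stated time of 24 h; a higher number here means a weaker inhibitor, a lower number a stronger inhibitor: in this assay compound 1 gives 500 ug/mL. Compound 2 `Fc1ccc(/C=N/NC(=S)Nc2cccc3ccccc23)cc1F` returns a limit of the assay rather than a number: in this assay compound 2 gives > 500 ug/mL. For the measured compounds named here, the single measured step, a number no lower from compound 1 to compound 2 (the limit leaves the size open), therefore leaves its size open, and what can be said about it rests on (the limit of > 500 ug/mL in this assay, at which 1 of the 2 values shown sits). Compound 3 `Fc1ccc(F)c(/C=N/NC(=S)Nc2cccc3ccccc23)c1` differs from compound 1 by 2,5-difluorophenyl in place of 3-chloro-4-fluorophenyl on a carbon with a double bond to nitrogen. Going by the values given here, no measured step reproduces exactly this change; the only one that bears on it is the step from compound 1 to compound 2, which likewise puts fluoro in place of chloro on an aromatic carbon and shows no lowering, with its size unreadable. On that basis one expects in this assay no step beyond the scatter, with a fair chance that the result is again only a limit; the expected step is no change at the digits printed from compound 1 to compound 3 (within the scatter). Compound 3 is accordingly estimated at 500 ug/mL, in a range from 250 ug/mL to 1000 ug/mL.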

Compound 3, half-maximal inhibitory concentration: > 500 ug/mL
Compound 3 ended at the assay's limit; the forecaster's own chance of this, stated with the estimate: 55%; the middle value sits exactly at the limit.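

In this assay the change gives a number no lower from compound 1 to compound 3 (the limit leaves the size open), so 2,5-difluorophenyl on the carbon with a double bond to nitrogen brings no lowering relative to the 3-chloro-4-fluorophenyl of compound 1. Until now only one difluorophenyl group, the 3,4-difluorophenyl of compound 2, stood against that chlorine-bearing group; compound 3 adds a second one with its two fluorines placed differently, and among the three compounds shown neither difluorophenyl group goes against this absence of lowering. The sizes of both steps, and any difference between compound 2 and compound 3, cannot be read, because the comparison ends at the assay's limit: the limit of > 500 ug/mL in this assay, at which 2 of the 3 values shown sit.

On these data alone, how far compound 2 and compound 3 lie past that limit stays open, and with it whether the placement of the two fluorines matters at all in this assay. Also open, as far as these compounds go, is whether a carboxylic acid or an amine on the same phenyl ring, in place of the halogens, would bring the number down within the readable range.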